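Working notes: from compound 2 to compound 3

A few compounds are considered here, and "the series" means these few. Any claim that something is new, unique, unknown or untested is made for them only; others in the source may bear on it.

Two compounds of this series have a number in a functional assay on BaF3 cells (Mus musculus) for inhibition, read by CCK-8 assay, with a stated time of 72 h (on this read-out higher numbers stand for weaker inhibition of growth and lower numbers for stronger inhibition of growth), so far. Compound 1 `CC(=O)Nc1cc(Oc2ccc(NC(=O)Nc3ccc(C)c(C(F)(F)F)c3)cc2)ncn1` gives 3230 nM in this assay. Among the compounds with values here, compound 2 `Cc1ccc(NC(=O)Nc2ccc(Oc3cc(N(C)CCN(C)C)ncn3)cc2)cc1C(F)(F)F` gives 9410 nM in this assay, the highest of the two numbers; its only neighbour is compound 1, and the change of a 2.9-fold higher number from compound 1 to compound 2 (0.46 log units; beyond the scatter) lies beyond the scatter.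

Compound 3 `C=CC(=O)Nc1cc(Oc2ccc(NC(=O)Nc3ccc(C)c(C(F)(F)F)c3)cc2)ncn1` is not yet measured. It differs from compound 2 by (vinylcarbonyl)amino in place of (2-(dimethylamino)ethyl)(methyl)amino on an aromatic carbon. Within the data shown here, the one measured step that bears on this change is the one from compound 1 to compound 2, in which the acetamido gave way to the (2-(dimethylamino)ethyl)(methyl)amino and the number rose by a 2.9-fold higher number from compound 1 to compound 2 (0.46 log units; beyond the scatter). Compound 3 undoes that exchange and puts in its place a (vinylcarbonyl)amino, a group close to the acetamido of compound 1. Among the measured compounds shown here, the expected step is therefore a move back down, roughly the size of the one from compound 1 to compound 2, with the estimate a 3.8-fold lower number from compound 2 to compound 3 (0.58 log units; beyond the scatter). Compound 3 is expected to give about 2500 nM in this assay, within a range of 700 nM to 9000 nM.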

Compound 3, concentration for 50% growth inhibition: 1940 nM
For compound 3 the middle estimate is 1.3-fold (0.11 log units) above the measured one, within the range that was stated.
By their numbers in this assay, from the lowest: compounds 3 and 1 (each within the scatter of the next); then compound 2.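

In this assay, (vinylcarbonyl)amino in place of (2-(dimethylamino)ethyl)(methyl)amino on this aromatic carbon, next to the ring nitrogen, gives a 4.9-fold lower number from compound 2 to compound 3 (0.69 log units; beyond the scatter), so the rise seen on going to the chain is not specific to the acetamido comparison: a second acylamino group also stands apart from compound 2. Vinyl in place of methyl on the carbonyl carbon gives a 1.7-fold lower number from compound 1 to compound 3 (0.22 log units; within the scatter), so the two acylamino groups cannot be told apart in this assay, and the vinyl adds nothing that can be read here over the methyl. Nothing at hand gives a reason for either step.

As far as these compounds go, with three compounds, the two acylamino groups differ from the chain in several counted features at once, among them the hydrogen-bond donor and the carbonyl, so it stays open which of these goes with the step. A free primary amine on this carbon, or a longer acyl chain such as propanoyl or butanoyl, would show whether the numbers follow the amide hydrogen, the carbonyl or the size of the group.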